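Moving the methoxy group: compound 2 to compound 3

A few compounds are considered here, and "the series" means these few. Any claim that something is new, unique, unknown or untested is made for them only; others in the source may bear on it.

In a functional assay on BGC-823 cells (Homo sapiens) for antiproliferative activity, read by MTT assay, with a stated time of 48 h (on this read-out higher numbers stand for weaker inhibition and lower numbers for stronger inhibition), compound 1 `S=c1oc(-c2ccc3c(c2)OCCO3)nn1CN1CCN(c2ccccc2)CC1` reads > 50000 nM, which is a limit of the assay. Going by the values given here, compound 2 `COc1ccccc1N1CCN(Cn2nc(-c3ccc4c(c3)OCCO4)oc2=S)CC1` gives 19500 nM, the only actual number so far. Compound 3 `COc1ccc(N2CCN(Cn3nc(-c4ccc5c(c4)OCCO5)oc3=S)CC2)cc1` has 4-methoxyphenyl in place of 2-methoxyphenyl on an amine nitrogen in a ring. Among the compounds with values here, the sole measured step, an at least 2.5-fold lower number from compound 1 to compound 2 (0.40 log units; beyond the scatter), adds a methoxy group but does not test where it sits, so no change beyond the scatter is expected. The expected step is a 1.1-fold lower number from compound 2 to compound 3 (0.03 log units; within the scatter). In this assay compound 3 is estimated at 18000 nM, with an expected range of 7000 nM to 50000 nM.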

Compound 3, half-maximal inhibitory concentration: 18900 nM
Compound 3: the middle estimate sits 1.1-fold (0.02 log units) below what was measured, and the stated range covers the measured number.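

In this assay, moving the group from 2-methoxyphenyl to 4-methoxyphenyl gives a 1.0-fold lower number from compound 2 to compound 3 (0.01 log units; within the scatter), so the two placements are not told apart here. Methoxy in place of hydrogen on an aromatic carbon, now as 4-methoxyphenyl, gives an at least 2.6-fold lower number from compound 1 to compound 3 (0.42 log units; beyond the scatter), so a step beyond the scatter is seen with both placements. Compound 1 stands at a limit, so the full size of that step cannot be read: the limit of > 50000 nM in this assay, at which 1 of the 3 values shown sits.

As far as these compounds go, whether an amine, a carboxylic acid or a longer chain in place of methoxy would move the number remains open.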